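This account rests on a few compounds, and the source may have more. Where it says the series, first, only, none or still open, it means among the compounds named here.

Compound 3 `COc1nc(N)nc2c1c(-c1ccsc1)cn2[C@@H]1O[C@H](CO)[C@@H](O)[C@H]1O` stands at the top of the measurable range in a functional assay on HeLa S3 cells (Homo sapiens) for antiproliferative activity, read by XTT assay, with a stated time of 72 h; a lower number here means a stronger inhibitor, a higher number a weaker inhibitor: compound 3 gives > 20000 nM, which is a limit and not a number. Compound 2 `COc1nc(N)nc2c1c(-c1ccco1)cn2[C@@H]1O[C@H](CO)[C@@H](O)[C@H]1O` gives > 20000 nM, also a limit. Compound 2 and compound 3 therefore both sit at the limit of > 20000 nM in this assay, at which 2 of the 3 values shown sit.

The next structure, compound 4 `C#Cc1cn([C@@H]2O[C@H](CO)[C@@H](O)[C@H]2O)c2nc(N)nc(OC)c12`, keeps the core of compound 3 but carries ethynyl in place of thiophen-3-yl on an aromatic carbon.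

Among the measured compounds shown here, only one measured step involves a change at this carbon, a step that the two limits leave unreadable from compound 2 to compound 3. It exchanges one aromatic ring for another and offers no size that could be carried over. The closest guide is compound 1 `C#Cc1cn([C@@H]2O[C@H](CO)[C@@H](O)[C@H]2O)c2ncnc(OC)c12`, which also bears ethynyl, although its core is not identical to that of compound 4. In this assay, compound 1 gives 1730 nM.

On the basis of compound 1 at 1730 nM, a move towards stronger inhibition is expected. Its size is uncertain, and a result at the limit remains possible. The estimated step is an at least 4.0-fold lower number from compound 3 to compound 4 (0.60 log units; beyond the scatter). Compound 4 is estimated at 5000 nM, with an expected range of 700 nM to 20000 nM.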

Compound 4, half-maximal inhibitory concentration: > 20000 nM
Compound 4 gave a limit, no number (the forecaster's own chance of this, stated with the estimate: 35%); at least 4.0-fold (0.60 log units) between middle value and limit.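

In this assay, among the compounds shown here, the only step that can be read is an at least 11-fold higher number from compound 1 to compound 4 (1.06 log units; beyond the scatter), and it is the first readable step: with ethynyl kept in place, the amino group is the one change that separates a compound with a measured number from a compound at the limit. Compound 4 gives > 20000 nM, which is a limit, so ethynyl on this carbon does not yield a measured number once the amino group is on the core. The steps among compound 2, compound 3 and compound 4 cannot be read, and the furan-2-yl, thiophen-3-yl and ethynyl compounds on the amino-bearing core now all sit at one boundary: the limit of > 20000 nM in this assay, at which 3 of the 4 values shown sit.

As far as these compounds go, how far these three compounds lie beyond that limit remains unknown, so no order among their groups can be given. From the compounds shown here alone, it also remains open whether a methyl group or a longer alkyne chain on this carbon would bring the amino-bearing core back into the measurable range, and whether furan-2-yl or thiophen-3-yl would give a number on the core of compound 1.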